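The source may report more compounds than this note shows. Statements on the series, on what has been measured and on what is new or still open speak of the compounds shown alone.

In an ADME assay on Vero cells (Chlorocebus sabaeus) for cytotoxicity, read by MTT assay, with a stated time of 72 h (a higher number here means that more compound is tolerated, a lower number that less compound is tolerated), compound 2 (`CCOC(=O)c1c(-c2ccccc2)oc2ccc(OCCCN3C(=O)/C(=N\OC)c4cc(OC)ccc43)cc12`) gives 64 ug/mL and compound 1 (`CCOC(=O)c1c(-c2ccc(OC)cc2)oc2ccc(OCCCN3C(=O)/C(=N\OC)c4ccccc43)cc12`) gives 128 ug/mL as its value, so the two numbers lie within the usual scatter of each other. Compound 3 (`CCOC(=O)c1c(-c2ccc(OC)cc2)oc2ccc(OCCCN3C(=O)/C(=N\OC)c4cc(OC)ccc43)cc12`) differs from compound 2 in one place (methoxy in place of hydrogen on an aromatic carbon), with methoxy in place of hydrogen on an aromatic carbon, so phenyl becomes 4-methoxyphenyl. Among the compounds with values here, no measured pair shows this change alone. Compound 1 at 128 ug/mL also carries 4-methoxyphenyl, so no step beyond the scatter is expected. The estimated step of a 1.4-fold higher number from compound 2 to compound 3 (0.15 log units; within the scatter) is slight and upward. For compound 3 the estimated value is 90 ug/mL with an expected range from 32 ug/mL to 256 ug/mL here.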

Compound 3, half-maximal cytotoxic concentration: 128 ug/mL
Beside the measured number, compound 3's estimate is 1.4-fold (0.15 log units) below it; the range from low to high includes it.
By their numbers in this assay, from the lowest: compounds 2, 1 and 3 (each within the scatter of the next).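

In this assay, methoxy in place of hydrogen on an aromatic carbon now has measured steps of its own: phenyl to 4-methoxyphenyl gives a 2.0-fold higher number from compound 2 to compound 3 (0.30 log units; within the scatter), and the same change at a second place in the molecule gives no change at the digits printed from compound 1 to compound 3 (within the scatter). Both steps lie within the scatter, so neither place shows a clear response to this change. Nothing available here bears on the reason for this result.

Still open, from the compounds shown here alone, is whether an amine or a carboxylic acid in place of that methoxy would move the number beyond the scatter.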